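Aryl swap at the saturated carbon: furan in place of bromophenyl

The source may hold more compounds than are shown below. What is called first, only, known or untested is meant among the compounds shown, and "the series" means these compounds.

Measured compounds:
compound 1 `CC(=O)N1N=C(c2cccc3ccccc23)CC1c1cccc(Cl)c1Cl` 20100 nM
compound 2 `CC(=O)N1N=C(c2cccc3ccccc23)CC1c1cccc(Br)c1` 12000 nM

In a functional assay on PC-3 cells (Homo sapiens) for cytotoxicity, read by sulforhodamine B assay, with a stated time of 48 h (on this read-out higher numbers stand for weaker inhibition and lower numbers for stronger inhibition), compound 1 gives 20100 nM and compound 2 gives 12000 nM. Among the compounds with values here, the only measured step, a 1.7-fold lower number from compound 1 to compound 2 (0.22 log units; within the scatter), is within the scatter, so compound 2 and compound 1 stand together rather than apart. Compound 3 `CC(=O)N1N=C(c2cccc3ccccc23)CC1c1ccco1` is not yet measured; it differs from compound 2 as follows: furan-2-yl in place of 3-bromophenyl on a saturated ring carbon. Within the data shown here, the step from compound 1 to compound 2 is the one comparison at this position, and it showed no change beyond the scatter when one aryl group replaced another; no measurement on a furan-2-yl group here exists. On this basis no step beyond the scatter is expected, in either direction, and compound 3 is expected to give about 15000 nM, with a range of 5000 nM to 50000 nM, which as a step means a 1.3-fold higher number from compound 2 to compound 3 (0.10 log units; within the scatter).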

Compound 3, half-maximal inhibitory concentration: 18000 nM
The estimate for compound 3 lay 1.2-fold (0.08 log units) below the measured number; the measured number falls inside the stated range.
By their numbers in this assay, from the lowest: compounds 2, 3 and 1 (each within the scatter of the next).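

In this assay the furan-2-yl group gives no separation from either aryl group, with a 1.5-fold higher number from compound 2 to compound 3 (0.18 log units; within the scatter) and a 1.1-fold lower number from compound 1 to compound 3 (0.05 log units; within the scatter) both reading as level comparisons. Within the data shown here, the earlier pair covered only one halogenated phenyl group against another, whereas this change replaces a six-membered aromatic ring of carbon with a smaller five-membered aromatic ring carrying one hetero atom, and removes all halogen, yet no step leaves the scatter. The saturated ring carbon therefore accepts this wider aryl change without a resolved shift among these three compounds.

Still open, going by these compounds, is whether a non-aromatic group at this carbon, such as an amine, a carboxylic acid or a longer alkyl chain, would produce a step beyond the scatter. Also open, on these data alone, is how the acetyl group contributes, as it is common to all three compounds. No available evidence bears on why these numbers stay together.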